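The source may report more compounds than this note shows. Statements on the series, on what has been measured and on what is new or still open speak of the compounds shown alone.

Measured in a functional assay on HT-29 cells (Homo sapiens) for inhibition, read by MTT assay, with a stated time of 72 h; a lower number here means a stronger inhibitor of growth, a higher number a weaker inhibitor of growth:
- compound 1 `O=S(=O)(NCCCCNCc1ccc(Br)cc1)c1cc(C(F)(F)F)cc(C(F)(F)F)c1` gives 1600 nM
- compound 2 `COc1ccc(CNCCCNS(=O)(=O)c2cc(C(F)(F)F)cc(C(F)(F)F)c2)cc1OC` gives 2700 nM
- compound 3 `O=S(=O)(NCCCNCc1ccc(Cl)c(C(F)(F)F)c1)c1cc(C(F)(F)F)cc(C(F)(F)F)c1` gives 11000 nM

Compound 3 gives the highest number of the three; compound 2 is nearest to it and compound 1 furthest, both with lower numbers. Compound 4 `O=S(=O)(NCCCNCc1ccccc1)c1cc(C(F)(F)F)cc(C(F)(F)F)c1` differs from compound 3 by phenyl in place of 4-chloro-3-(trifluoromethyl)phenyl on a saturated chain carbon bound to an amine nitrogen. Among the compounds with values here, the only step at the same place is a 4.1-fold higher number from compound 2 to compound 3 (0.61 log units; beyond the scatter), which shows that swapping the aryl group on that chain carbon moves this assay by a modest amount. Removing the chloro and trifluoromethyl groups is expected to move the number back toward the others, a modest step of a 2.2-fold lower number from compound 3 to compound 4 (0.34 log units; beyond the scatter). Compound 4 is therefore estimated at 5000 nM, within 1500 nM to 15000 nM.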

Compound 4, concentration for 50% growth inhibition: 15000 nM
Estimate against measurement, compound 4: 3.0-fold (0.48 log units) below; the measured number falls inside the stated range.
By their numbers in this assay, from the lowest: compounds 1 and 2 (each within the scatter of the next); then compounds 3 and 4 (each within the scatter of the next).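

In this assay, phenyl in place of 4-chloro-3-(trifluoromethyl)phenyl on a saturated chain carbon bound to an amine nitrogen gives a 1.4-fold higher number from compound 3 to compound 4 (0.13 log units; within the scatter), so the chloro and trifluoromethyl groups together make no readable difference at this place. Phenyl in place of 3,4-dimethoxyphenyl gives a 5.6-fold higher number from compound 2 to compound 4 (0.74 log units; beyond the scatter), which sets compound 2 apart from compound 3 and compound 4. Benzylamino in place of ((4-bromobenzyl)amino)methyl gives a 9.4-fold higher number from compound 1 to compound 4 (0.97 log units; beyond the scatter), a change too broad to assign to one part.

Nothing shown bears on the cause of these steps. From the compounds shown here alone, whether a single methoxy group or a pyridine ring at this place would track compound 2 or compound 4 remains open.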